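Chloro Position Shift on the Benzamide of Compound 2

The source may report more compounds than this note shows. Statements on the series, on what has been measured and on what is new or still open speak of the compounds shown alone.

Measured so far:
compound 1 `COc1ccc(-c2cccc(C(=O)N(C)C)c2)cc1S(=O)(=O)Nc1cccc(NCCNC(=O)c2ccccc2C)c1` — 800 nM
compound 2 `COc1ccc(-c2cccc(C(=O)N(C)C)c2)cc1S(=O)(=O)Nc1cccc(NCCNC(=O)c2ccccc2Cl)c1` — 31 nM

In an assay on CHO-K1 cells for agonist activity at Orexin receptor type 2 (Homo sapiens), read by a luciferase reporter (a lower number here means that less compound is needed, a higher number that more compound is needed for the effect), compound 2 gives 31 nM, the lowest of the two numbers; compound 1 gives 800 nM. For the measured compounds named here, the single measured step, a 26-fold lower number from compound 1 to compound 2 (1.41 log units; beyond the scatter), is large. Compound 3 `COc1ccc(-c2cccc(C(=O)N(C)C)c2)cc1S(=O)(=O)Nc1cccc(NCCNC(=O)c2cccc(Cl)c2)c1` differs from compound 2 by 3-chlorophenyl in place of 2-chlorophenyl on a carbonyl carbon. Going by the values given here, no measured step moves a group to another ring position; the only step swaps the group at one position, so it bears on this change only indirectly. A moderate rise is expected, a 3.2-fold higher number from compound 2 to compound 3 (0.51 log units; beyond the scatter). Compound 3 is therefore estimated at 100 nM, with a range of 20 nM to 500 nM.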

Compound 3, half-maximal effective concentration: 94 nM
For compound 3 the middle estimate is 1.1-fold (0.03 log units) above the measured one; the range from low to high includes it.
By their numbers in this assay, from the lowest: compound 2; then compound 3; then compound 1.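

In this assay the step from 2-chlorophenyl to 3-chlorophenyl on the carbonyl carbon gives a 3.0-fold higher number from compound 2 to compound 3 (0.48 log units; beyond the scatter), so the place of the chlorine on this ring matters as well as its presence. The 3-chlorophenyl group still retains much of the gain over 2-methylphenyl, with an 8.5-fold lower number from compound 1 to compound 3 (0.93 log units; beyond the scatter) on that comparison. Nothing available here accounts for this difference between the two chlorophenyl groups. Still open, going by these compounds, is how 3-methylphenyl would stand against 3-chlorophenyl, and whether a pyridine ring or a carboxylic acid is tolerated on this carbonyl carbon.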